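The compounds below may be only part of what the source reports. "The series", "measured", "known", "first", "only" and "open" are said of these compounds alone.

Measured so far:
Compound 1, `CC(C)CNC1Oc2ccc(C(=O)c3ccccc3)c(O)c2NC1(C)C`: in a functional assay on HT-22 cells (Mus musculus), read by MTT assay (on this read-out lower numbers stand for higher toxicity in this test and higher numbers for lower toxicity in this test), compound 1 gives 45 uM.
Compound 2, `CC1(C)Nc2c(ccc(C(=O)c3ccccc3)c2O)OC1N1CCCCC1`: in this assay compound 2 gives 72 uM.

Going by the values given here, compound 2 carries one of only two numbers so far, and the single step between them, a 1.6-fold higher number from compound 1 to compound 2 (0.20 log units; within the scatter), lies within the scatter, so the two compounds cannot be told apart on this read-out. Both share a core in which an amine group sits on a saturated ring carbon of the fused ring system, and that amine is the only place where they differ.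

Compound 3, `CC1(C)Nc2c(ccc(C(=O)c3ccccc3)c2O)OC1O`, changes that same position: hydroxy in place of piperidin-1-yl on a saturated ring carbon. Among the compounds with values here, no measured step exchanges the group on this carbon for a hydroxy, so nothing bears on the change directly. Within the data shown here, the one step that touches this position, the swap of one amine for another from compound 1 to compound 2, left the number within the scatter. On that basis the expectation for compound 3 in this assay is a step of no more than the scatter, in no settled direction, a 1.2-fold lower number from compound 2 to compound 3 (0.08 log units; within the scatter). Compound 3 is therefore estimated to give 60 uM, in the range from 25 uM to 150 uM.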

Compound 3, half-maximal toxic concentration: 48 uM
Compound 3: middle estimate off by 1.3-fold (0.10 log units), on the high side, and the stated range covers the measured number.
By their numbers in this assay, from the lowest: compounds 1, 3 and 2 (each within the scatter of the next).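

Placing hydroxy on this saturated ring carbon gives, in this assay, a 1.5-fold lower number from compound 2 to compound 3 (0.18 log units; within the scatter) when it replaces piperidin-1-yl, and a 1.1-fold higher number from compound 1 to compound 3 (0.03 log units; within the scatter) when it replaces isobutylamino. The earlier step only compared one amine with another, whereas this result brings in a group with no nitrogen and no ring, yet all three compounds remain within the scatter of one another and cannot be told apart on this read-out. So neither an amine nitrogen on this carbon nor the six-membered ring of piperidin-1-yl is needed for a number in this range, and no supporting measurement is available to explain that outcome.

Going by these compounds, the three groups compared here are an open-chain amine, a ring amine and a hydroxy, so it remains open whether a carboxylic acid, a methoxy or a longer carbon chain on this carbon would give a step beyond the scatter. All three compounds also share the rest of the core, which leaves open how much changes elsewhere on it would matter in this assay.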